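From 1-benzofuran-2-yl to iodo on the shared core

This account rests on a few compounds, and the source may have more. Where it says the series, first, only, none or still open, it means among the compounds named here.

Values from a functional assay on K562 cells (Homo sapiens), read by MTT assay, with a stated time of 72 h (on this read-out higher numbers stand for weaker inhibition and lower numbers for stronger inhibition), follow.
- compound 1 `Cc1nc(N)c2c(-c3cccs3)cn([C@@H]3O[C@H](CO)[C@@H](O)[C@H]3O)c2n1` gives > 20000 nM (a limit)
- compound 2 `Cc1nc(N)c2c(-c3ccsc3)cn([C@@H]3O[C@H](CO)[C@@H](O)[C@H]3O)c2n1` gives > 20000 nM (a limit)
- compound 3 `Cc1nc(N)c2c(-c3cc4ccccc4o3)cn([C@@H]3O[C@H](CO)[C@@H](O)[C@H]3O)c2n1` gives 15700 nM (a number)

Within the data shown here, compound 3 holds the only number in the set, and the other two values are limits (the limit of > 20000 nM in this assay, at which 2 of the 3 values shown sit). The next change leads to compound 4 `Cc1nc(N)c2c(I)cn([C@@H]3O[C@H](CO)[C@@H](O)[C@H]3O)c2n1` and puts iodo in place of 1-benzofuran-2-yl on an aromatic carbon.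

Three measured steps swap one ring-bearing group for another at this carbon. The two that reach compound 3 are an at least 1.2-fold lower number from compound 1 to compound 3 (0.10 log units; that floor lies within the scatter) and an at least 1.2-fold lower number from compound 2 to compound 3 (0.10 log units; that floor lies within the scatter), and neither floor gives a readable size. The third is a step that the two limits leave unreadable from compound 1 to compound 2 and adds nothing on size. Among the measured compounds shown here, no measured compound has a group without a ring at this carbon, so these steps give no direct measure of the change to iodo.

In this assay, as far as these compounds go, no step beyond the scatter is therefore expected, and the direction stays open. The starting point is compound 3 at 15700 nM. A limit for compound 4 remains possible. The expected step is a 1.6-fold lower number from compound 3 to compound 4 (0.20 log units; within the scatter), with wide margins. For compound 4 the estimate is 10000 nM, with an expected range from 1500 nM to 30000 nM.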

Compound 4, half-maximal inhibitory concentration: 5120 nM
Beside the measured number, compound 4's estimate is 2.0-fold (0.29 log units) above it; measured number inside the range.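

In this assay this carbon now gives a step of readable size, a 3.1-fold lower number from compound 3 to compound 4 (0.49 log units; beyond the scatter) as iodo, a group with no ring, replaces the ring-bearing 1-benzofuran-2-yl. The two thiophene compounds give only floors, an at least 3.9-fold lower number from compound 2 to compound 4 (0.59 log units; beyond the scatter) and an at least 3.9-fold lower number from compound 1 to compound 4 (0.59 log units; beyond the scatter) on the change to iodo, yet both floors lie beyond the scatter, whereas the floors among the ring-bearing groups lay within it or could not be read. So the position does respond to the group it carries, and among the compounds shown, the lowest number belongs to the one group without a ring, though the floors rest on limits and not on numbers: the limit of > 20000 nM in this assay, at which 2 of the 4 values shown sit.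

With iodo the only group without a ring here, the compounds shown cannot tell whether the lower number goes with iodine itself or simply with the absence of a ring-bearing group. Bromo, chloro, an amine, a nitrile or a short alkyl chain at this carbon would separate these two readings, and a phenyl ring would show how far the ring-bearing groups themselves differ.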